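One swapped group, and what to expect from it

The source may report more compounds than this note shows. Statements on the series, on what has been measured and on what is new or still open speak of the compounds shown alone.

In a physicochemical assay for lipophilicity, at pH 7.4 (on this read-out higher numbers stand for higher lipophilicity and lower numbers for lower lipophilicity), compound 1 `Cc1cc(C(=O)Nc2c(F)cccc2F)nn1Cc1cc(Cl)ccc1OCc1ccccc1` gives 3.7, the highest of three numbers. Compound 3 `Cc1cc(C(=O)NN2CCCCC2)nn1Cc1cc(Cl)ccc1OCC(C)C` gives 3.3 and compound 2 `Cc1cc(C(N)=O)nn1Cc1cc(Cl)ccc1OCC(C)C` gives 3.1, both beyond the scatter from compound 1. Compound 4 `Cc1cc(NC(=O)CC(C)(C)C)nn1Cc1cc(Cl)ccc1OCc1ccccc1` has (neopentylcarbonyl)amino in place of (2,6-difluorophenyl)carbamoyl on an aromatic carbon. For the measured compounds named here, no measured pair makes this exact swap. Going by the values given here, the one measured step that bears on it is a number 0.20 log units higher from compound 2 to compound 3 (within the scatter), a different change that stayed within the scatter, so it guides only loosely. A small downward move is therefore expected in this assay, a number 0.20 log units lower from compound 1 to compound 4 (within the scatter), which would not go beyond the scatter. The estimate for compound 4 is 3.5, with an expected range of 3.1 to 3.9.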

Compound 4, distribution coefficient: > 3.7
Compound 4: no number, only a limit; the forecaster's own chance of this, stated with the estimate: 3%; at least 0.20 log units between middle value and limit.
By their numbers in this assay, from the lowest: compounds 2 and 3 (each within the scatter of the next); then compound 1.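

Compound 4 carries a limit of the assay and not a number, and that limit is where the reading stops: the limit of > 3.7 in this assay, at which 1 of the 4 values shown sits. In this assay the swap at this aromatic carbon gives a number no lower from compound 1 to compound 4 (the limit leaves the size open). Putting (neopentylcarbonyl)amino, which has no ring, in place of (2,6-difluorophenyl)carbamoyl therefore does not bring the reading down, though the step's size cannot be read.

On these data alone, whether a shorter acyl group such as acetylamino, or a plain amine, on this aromatic carbon would give a readable number remains open. So does how such groups would stand against compound 1.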